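The compounds below may be only part of what the source reports. "The series", "measured", "known", "first", "only" and "open" are said of these compounds alone.

Working notes on the series, read in a functional assay on HeLa cells (Homo sapiens) for cytotoxicity, read by MTT assay, with a stated time of 48 h; on this read-out higher numbers stand for weaker inhibition and lower numbers for stronger inhibition. Going by the values given here, compound 1 (`CCCCCCC(O)C/C=C\CCCCCCCC1=NNC2SCC(c3ccccc3)=NN12`) gives 8830 nM and compound 2 (`CCCC/C=C\CCC(O)CCCCCCC1=NNC2SCC(c3ccccc3)=NN12`) gives 6000 nM, so compound 2 stands within the scatter of the only other measured value. Compound 3 (`C=CCCCCCCCCC1=NNC2SCC(c3ccccc3)=NN12`) is still unmeasured and differs from compound 2 by but-3-en-1-yl in place of 1-hydroxynon-4-en-1-yl on a saturated chain carbon, six bonds along the chain from a carbon with a double bond to nitrogen. Among the compounds with values here, no measured pair shows a comparable change. The expected step is a small rise, not beyond the scatter, a 1.2-fold higher number from compound 2 to compound 3 (0.07 log units; within the scatter). The estimate for compound 3 is 7000 nM, with an expected range of 2500 nM to 20000 nM.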

Compound 3, half-maximal inhibitory concentration: 8010 nM
For compound 3 the middle estimate is 1.1-fold (0.06 log units) below the measured one; the measured number falls inside the stated range.
By their numbers in this assay, from the lowest: compounds 2, 3 and 1 (each within the scatter of the next).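

In this assay, but-3-en-1-yl in place of 1-hydroxynon-4-en-1-yl gives a 1.3-fold higher number from compound 2 to compound 3 (0.13 log units; within the scatter), and allyl in place of 4-hydroxydec-1-en-1-yl gives a 1.1-fold lower number from compound 1 to compound 3 (0.04 log units; within the scatter). At this saturated chain carbon, then, neither the hydroxyl nor the extra chain length is needed to keep the number in this range. No measurement on hand accounts for the three values lying together.

On these data alone, whether an amine or a carboxylic acid on the chain would give a step beyond the scatter remains open. Both steps alter the hydroxyl and chain length together, so the two stay unseparated.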